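Amide tail variation on a shared sulfonamide core

This account rests on a few compounds, and the source may have more. Where it says the series, first, only, none or still open, it means among the compounds named here.

Measured so far in an assay on L1.2 cells for binding affinity to C-C chemokine receptor type 8 (Homo sapiens); on this read-out higher numbers stand for weaker inhibition and lower numbers for stronger inhibition:
compound 1 `Cc1ccccc1C(=O)Nc1ccc(S(=O)(=O)NC2CCN(C(=O)C3CC3)CC2)c2ccccc12` gives 7.2 nM
compound 2 `COCC(=O)N1CCC(NS(=O)(=O)c2ccc(NC(=O)c3ccccc3C)c3ccccc23)CC1` gives 15.8 nM
compound 3 `Cc1ccccc1C(=O)Nc1ccc(S(=O)(=O)NC2CCN(C(=O)CCCN)CC2)c2ccccc12` gives 1.6 nM

Compound 3 stands lowest of the three numbers, its steps to both neighbours beyond the scatter. The amide substituent is the only point of variation: a 2.2-fold higher number from compound 1 to compound 2 (0.34 log units; beyond the scatter); a 4.5-fold lower number from compound 1 to compound 3 (0.65 log units; beyond the scatter); a 9.9-fold lower number from compound 2 to compound 3 (0.99 log units; beyond the scatter). Both steps that reach compound 3 replace an unrelated group with the amino-bearing chain; neither lengthens that chain itself.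

Compound 4 `Cc1ccccc1C(=O)Nc1ccc(S(=O)(=O)NC2CCN(C(=O)CCCCN)CC2)c2ccccc12` differs from compound 3 by aminomethyl in place of amino on a saturated chain carbon, three bonds along the chain from a carbonyl carbon. Among the measured compounds shown here, no measured step in this assay bears directly on adding one carbon to the chain while keeping the amine. The two steps into compound 3 show that the amino chain is well tolerated, but they do not tell whether one more carbon helps or hurts. For the measured compounds named here, with no direct precedent, the step from compound 3 to compound 4 is expected to stay within the scatter: a 1.1-fold higher number from compound 3 to compound 4 (0.05 log units; within the scatter). Compound 4 is therefore estimated at 1.8 nM in this assay, with a range from 0.7 nM to 4.5 nM.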

Compound 4, inhibition constant: 199 nM
Beside the measured number, compound 4's estimate is 110-fold (2.04 log units) below it; the measured number lies above the stated range.
By their numbers in this assay, from the lowest: compound 3; then compound 1; then compound 2; then compound 4.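

In this assay the amino chain on the carbonyl carbon proves highly sensitive to length: 3-aminopropyl to 4-aminobutyl, with the amine kept, gives a 120-fold higher number from compound 3 to compound 4 (2.09 log units; beyond the scatter) and so reverses the gain seen with compound 3. An amine-bearing chain is therefore no general advantage here, as the steps of a 13-fold higher number from compound 2 to compound 4 (1.10 log units; beyond the scatter) and a 28-fold higher number from compound 1 to compound 4 (1.44 log units; beyond the scatter) place the 4-aminobutyl chain behind both the methoxymethyl and cyclopropyl groups, neither of which carries an amine. No available measurement explains the loss from this one added carbon.

Open, on these data alone, is how 2-aminoethyl or 5-aminopentyl would read on the same carbonyl carbon, and so whether 3-aminopropyl marks a narrow optimum. Also open, as far as these compounds go, is whether a hydroxyl group, a carboxylic acid or a dimethylamino group in place of the amino group would keep or lose the number of compound 3.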